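The source may report more compounds than this note shows. Statements on the series, on what has been measured and on what is new or still open speak of the compounds shown alone.

Compound 3 `COc1ccc2c(c1)c(C1CC(c3ccc(F)cc3)=NN1C(=O)c1ccc(OC)nc1)cn2C` gives > 300000 nM in an ADME assay on HEK-293T cells (Homo sapiens) for cytotoxicity, read by MTT assay, with a stated time of 48 h (a higher number here means that more compound is tolerated, a lower number that less compound is tolerated), as a limit and not a number. Compound 2 `COc1ccc2c(c1)c(C1CC(c3ccccc3)=NN1C(=O)c1ccc(OC)nc1)cn2C` gives > 300000 nM as a limit too. Compound 1 `Cn1cc(C2CC(c3ccccc3)=NN2C(=O)c2cccnc2)c2cc(Br)ccc21` gives > 300000 nM as a limit as well. Among the measured compounds shown here, the series so far therefore rests on the limit of > 300000 nM in this assay, at which 3 of the 3 values shown sit, and holds no readable number.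

Compound 4 `COc1ccc2c(c1)c(C1CC(c3ccc(Br)cc3)=NN1C(=O)c1ccc(OC)nc1)cn2C` departs from compound 3 by bromo in place of fluoro on an aromatic carbon and reads as 4-fluorophenyl to 4-bromophenyl. For the measured compounds named here, the one measured step that bears on it is a step that the two limits leave unreadable from compound 2 to compound 3 and offers no size to carry over. The estimated step is a number no higher from compound 3 to compound 4 (the limit leaves the size open) with none expected beyond the scatter in this assay because compound 3 shares the limit of > 300000 nM in this assay, at which 3 of the 3 values shown sit, with compound 1 and compound 2. For compound 4 the expected value is 300000 nM with an estimated range of 150000 nM to 600000 nM and most probably only a limit reported.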

Compound 4, half-maximal cytotoxic concentration: > 300000 nM
Compound 4: only a limit was reported (the forecaster's own chance of this, stated with the estimate: 85%); the middle value sits exactly at the limit.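

Among the compounds shown here, no step to compound 4 can be read from compound 2 or compound 3, as all three carry only a limit. The compounds shown leave open whether hydrogen, fluoro or bromo makes any difference in this assay.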